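A few compounds are considered here, and "the series" means these few. Any claim that something is new, unique, unknown or untested is made for them only; others in the source may bear on it.

The measured compounds:

Compound 1, `FC(F)(F)c1ccc(CSc2nc(Nc3ccccc3C(F)(F)F)c3ccccc3n2)cc1`, gives only a limit of the assay in a functional assay on HGC-27 cells (Homo sapiens) for cytotoxicity, read by MTT assay, with a stated time of 72 h; on this read-out higher numbers stand for weaker inhibition and lower numbers for stronger inhibition: > 50000 nM.
Compound 2, `FC(F)(F)c1ccc(CSc2nc(Nc3cccc(C(F)(F)F)c3)c3ccccc3n2)cc1`, gives 11700 nM in this assay.

Compound 1 therefore stands at the weak end of what has been measured; its value is a limit, not a number, and the shared core with a 2-(trifluoromethyl)phenyl on the ring nitrogen is one of the two values that sit at that limit (the limit of > 50000 nM in this assay, at which 1 of the 2 values shown sits). Compound 3, `FC(F)(F)c1ccc(CSc2nc(Nc3cccc(Cl)c3)c3ccccc3n2)cc1`, differs from compound 1 in one place: 3-chlorophenyl in place of 2-(trifluoromethyl)phenyl on a nitrogen on an aromatic ring. Going by the values given here, the one measured step that bears on this change is the move of the trifluoromethyl group from the 2-position to the 3-position of the phenyl, an at least 4.2-fold lower number from compound 1 to compound 2 (0.63 log units; beyond the scatter), which carried the number below the limit by a modest margin. Compound 3 also carries its substituent at the 3-position, now a chlorine in place of trifluoromethyl, for which no measured comparison exists here. Compound 3 is therefore expected to give a lower number than compound 1 in this assay, a step of about an at least 3.5-fold lower number from compound 1 to compound 3 (0.55 log units; beyond the scatter), with a real chance that the assay again reports only a limit. The estimate for compound 3 is 14000 nM, between 4500 nM and 50000 nM.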

Compound 3, half-maximal inhibitory concentration: 19900 nM
Estimate against measurement, compound 3: 1.4-fold (0.15 log units) below; the range from low to high includes it.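

In this assay, 3-chlorophenyl in place of 2-(trifluoromethyl)phenyl on a nitrogen on an aromatic ring gives an at least 2.5-fold lower number from compound 1 to compound 3 (0.40 log units; beyond the scatter), so 3-(trifluoromethyl)phenyl is no longer the only group shown here that gives a measured number rather than a limit. Chloro in place of trifluoromethyl on an aromatic carbon gives a 1.7-fold higher number from compound 2 to compound 3 (0.23 log units; within the scatter), so compound 2 and compound 3 cannot be told apart on this read-out, and this exchange of groups shows no change beyond the usual scatter. The value of compound 1 remains a limit and not a number: the limit of > 50000 nM in this assay, at which 1 of the 3 values shown sits.

Compound 1 and compound 3 differ both in the group on the phenyl and in where it stands, and the compounds shown do not separate these two differences. They also leave open how an amine, a methoxy group or a carboxylic acid on that phenyl would read in this assay, and whether a change elsewhere on the shared core could lower the number further.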